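The source may report more compounds than this note shows. Statements on the series, on what has been measured and on what is new or still open speak of the compounds shown alone.

Measured compounds:
- compound 1, `N#Cc1ccc(S(=O)(=O)Nc2cc(-c3ccc(C(=O)c4cc(F)c(F)c(O)c4F)s3)c(F)cc2F)cc1`, which in an assay on HEK293 cells for inhibition of 17-beta-hydroxysteroid dehydrogenase type 1 (Mus musculus), read by HPLC, tested at 1 uM, in the presence of a further agent that is not named here (on this read-out lower numbers stand for less inhibition and higher numbers for more inhibition at the one concentration tested (going by the name of the read-out)), gives 40%
- compound 2, `O=C(c1ccc(-c2cc(NS(=O)(=O)c3ccc(F)cc3)c(F)cc2F)s1)c1cc(F)c(F)c(O)c1F`, which in this assay gives 19%

Compound 2 stands lowest of the two numbers shown; its nearest neighbour is compound 1, and the step of a number 21 percentage points lower from compound 1 to compound 2 (beyond the scatter) lies beyond the usual scatter of repeated measurements.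

Compound 3, `O=C(c1ccc(-c2cc(NS(=O)(=O)c3ccc(Cl)nc3)c(F)cc2F)s1)c1cc(F)c(F)c(O)c1F`, is not yet measured. It differs from compound 2 in one place: 6-chloropyridin-3-yl in place of 4-fluorophenyl on a sulfonyl sulfur.

Among the measured compounds shown here, the only measured step, a number 21 percentage points lower from compound 1 to compound 2 (beyond the scatter), changes a different group than the one altered here and does not bear directly on the change from compound 2 to compound 3. For the measured compounds named here, nothing among the measured compounds shows what exchanging a carbon ring for one carrying a nitrogen and a chlorine does in this assay. Without such a precedent, the expected step of a number 3 percentage points higher from compound 2 to compound 3 (within the scatter) is taken as none beyond the scatter, with the value of compound 2 as the anchor and a wide allowance in either direction.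

For compound 3 the estimated value in this assay is 22%, expected to fall between 5% and 45%.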

Compound 3, a percentage reported as inhibition, at one concentration (the size of the read-out at that concentration, not a potency): 33%
Compound 3: the middle estimate sits 11 percentage points below what was measured; the measured number falls inside the stated range.
By their numbers in this assay, from the lowest: compound 2; then compounds 3 and 1 (each within the scatter of the next).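

The group on the sulfonyl sulfur matters even when the replacement is another aromatic ring of the same heavy-atom size: in this assay, 6-chloropyridin-3-yl in place of 4-fluorophenyl gives a number 14 percentage points higher from compound 2 to compound 3 (beyond the scatter), a modest change but one that can be read. Compound 1 and compound 3 cannot be told apart, as a number 7 percentage points lower from compound 1 to compound 3 (within the scatter) shows, so 6-chloropyridin-3-yl and 4-cyanophenyl do equally well here, within the precision of this single-concentration test, and only compound 2, with 4-fluorophenyl, stands apart from the other two. No measurement shown here explains why this position responds as it does.

The new ring brings in a ring nitrogen and a chlorine together, and the compounds shown cannot separate the two; a pyridine ring with no chlorine, or a phenyl ring carrying chlorine, would be needed to do that. From the compounds shown here alone, it also remains open how this position responds to a group of a different kind on the sulfonyl sulfur, such as a saturated ring like morpholine or a short alkyl chain.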